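Replacing the Carboxypyrrolidine Group on the Shared Core

This account rests on a few compounds, and the source may have more. Where it says the series, first, only, none or still open, it means among the compounds named here.

Measured in a functional assay on HeLa cells (Homo sapiens) for antiproliferative activity, read by CCK-8 assay, with a stated time of 48 h; a higher number here means a weaker inhibitor, a lower number a stronger inhibitor:
Compound 1 `COc1ccc(/C=C\c2cc(OC)c(OC)c(OC)c2)cc1OCc1ccc(CNCCO)cc1`: 4400 nM
Compound 2 `COc1ccc(/C=C\c2cc(OC)c(OC)c(OC)c2)cc1OCc1ccc(CN2CC[C@H](C(=O)O)C2)cc1`: > 10000 nM

Compound 2 reads > 10000 nM, which is a limit of the assay and not a number. Compound 3 `COc1ccc(/C=C\c2cc(OC)c(OC)c(OC)c2)cc1OCc1ccc(CN2CCCCC2C(=O)NCCN)cc1` makes one change to it: 2-((2-aminoethyl)carbamoyl)piperidin-1-yl in place of 3-carboxypyrrolidin-1-yl on a saturated chain carbon bound to an aromatic carbon. Among the compounds with values here, the only measured step, an at least 2.2-fold higher number from compound 1 to compound 2 (0.35 log units; beyond the scatter), introduced the 3-carboxypyrrolidin-1-yl group that now leaves. With that group gone, the number is expected to move back towards that of compound 1, at 4400 nM. In this assay, the expected change is a lower number, an at least 2.8-fold lower number from compound 2 to compound 3 (0.45 log units; beyond the scatter). For compound 3 the estimate is 3500 nM, with an expected range of 900 nM to 10000 nM.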

Compound 3, half-maximal inhibitory concentration: 7300 nM
The estimate for compound 3 lay 2.1-fold (0.32 log units) below the measured number; measured number inside the range.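

In this assay, the 2-((2-aminoethyl)carbamoyl)piperidin-1-yl group gives a real number on this saturated chain carbon, whereas compound 2, with 3-carboxypyrrolidin-1-yl, gives only a limit: the limit of > 10000 nM in this assay, at which 1 of the 3 values shown sits.

As far as these compounds go, the change reads as an at least 1.3-fold lower number from compound 2 to compound 3 (0.13 log units; that floor lies within the scatter), so its true size remains unknown. Against the (2-hydroxyethyl)amino group, it reads as a 1.7-fold higher number from compound 1 to compound 3 (0.22 log units; within the scatter), so these two groups cannot be told apart here.

Still open, from the compounds shown here alone, is whether a plain piperidin-1-yl group, without the carbamoyl chain, would read differently. The same question applies to a longer chain on the amide nitrogen.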